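Fluoro in place of bromo: working notes on the series

A few compounds are considered here, and "the series" means these few. Any claim that something is new, unique, unknown or untested is made for them only; others in the source may bear on it.

- compound 1 `COc1cccc(C(=O)N2CCN(CC(=O)N3CCN(CCCc4c[nH]c5ccc(F)cc45)CC3)CC2)c1` gives 79400 nM
- compound 2 `O=C(CN1CCN(C(=O)c2cccc(Br)c2)CC1)N1CCN(CCCc2c[nH]c3ccc(F)cc23)CC1` gives 71600 nM

In an ADME assay on SH-SY5Y cells (Homo sapiens) for cytotoxicity, read by MTT assay, with a stated time of 72 h (on this read-out lower numbers stand for stronger inhibition and higher numbers for weaker inhibition), compound 2 gives 71600 nM and sits within the scatter of compound 1. The change to compound 3 `O=C(CN1CCN(C(=O)c2cccc(F)c2)CC1)N1CCN(CCCc2c[nH]c3ccc(F)cc23)CC1` is fluoro in place of bromo on an aromatic carbon and amounts to fluoro in place of bromo on an aromatic carbon. Among the measured compounds shown here, the one measured step bearing on it is a 1.1-fold lower number from compound 1 to compound 2 (0.04 log units; within the scatter) and lies within the scatter. For the measured compounds named here, no measured step has fluoro entering. No step beyond the scatter is therefore expected in this assay for this swap. The estimated step is a 1.0-fold higher number from compound 2 to compound 3 (0.02 log units; within the scatter) on this reading. Compound 3 is expected at 75000 nM with an estimated range from 45000 nM to 120000 nM for now.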

Compound 3, half-maximal inhibitory concentration: 169000 nM
For compound 3 the middle estimate is 2.3-fold (0.35 log units) below the measured one; the whole stated range lies below it.
By their numbers in this assay, from the lowest: compounds 2 and 1 (each within the scatter of the next); then compound 3.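

In this assay, this place on the ring is not indifferent to its substituent: bromo and methoxy stay within the scatter of each other, but 3-fluorophenyl separates from both, with a 2.4-fold higher number from compound 2 to compound 3 (0.37 log units; beyond the scatter) and a 2.1-fold higher number from compound 1 to compound 3 (0.33 log units; beyond the scatter). Both steps are modest and point the same way, towards a higher number with fluoro. Nothing available explains this result.

As far as these compounds go, what a chloro, an amino group or a carboxylic acid would give at this place remains open. Also open, from the compounds shown here alone, is whether fluoro elsewhere on this ring gives a similar step.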